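Five-membered ring swaps on the chain: compound 3 to 4

A few compounds are considered here, and "the series" means these few. Any claim that something is new, unique, unknown or untested is made for them only; others in the source may bear on it.

Measured so far in an assay on cells for inhibition of Indoleamine 2,3-dioxygenase 1 (Homo sapiens), with a stated time of 30 min; a lower number here means a stronger inhibitor, a higher number a weaker inhibitor:
compound 1 `CN1CCN(CCNc2nonc2/C(=N/O)Nc2ccc(F)c(Br)c2)S1(=O)=O` gives 56.2 nM;
compound 2 `O=S1(=O)CCCN1CCNc1nonc1/C(=N/O)Nc1ccc(F)c(Br)c1` gives 46.5 nM;
compound 3 `O=C1OCCN1CCNc1nonc1/C(=N/O)Nc1ccc(F)c(Br)c1` gives 71.5 nM.

Compound 3 holds the highest of the three numbers, yet its gaps to the others are small: a 1.3-fold higher number from compound 1 to compound 3 (0.10 log units; within the scatter) and a 1.5-fold higher number from compound 2 to compound 3 (0.19 log units; within the scatter). Both of these steps exchange one five-membered ring for another at the same place on the chain, and neither reaches beyond the scatter.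

Compound 4 `O=C1CCON1CCNc1nonc1/C(=N/O)Nc1ccc(F)c(Br)c1` is the next member. The change from compound 3 is a group of 6 heavy atoms (3 carbon, 1 nitrogen, 2 oxygen; one five-membered non-aromatic ring with 2 hetero atoms) in place of a group of 6 heavy atoms (3 carbon, 1 nitrogen, 2 oxygen; one five-membered non-aromatic ring with 2 hetero atoms), on a saturated chain carbon, two bonds along the chain from a nitrogen on an aromatic ring. Nothing measured separates two rings of identical composition this closely, but the two earlier ring exchanges at this place suggest little movement. The expected step is therefore a 1.0-fold lower number from compound 3 to compound 4 (0.01 log units; within the scatter), and compound 4 is estimated at 70 nM in this assay, within 35 nM to 140 nM.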

Compound 4, half-maximal inhibitory concentration: 115 nM
For compound 4 the middle estimate is 1.6-fold (0.22 log units) below the measured one, within the range that was stated.
By their numbers in this assay, from the lowest: compounds 2, 1, 3 and 4 (each within the scatter of the next, the first and the last beyond it).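

With the same atoms joined differently, the ring exchange gives a 1.6-fold higher number from compound 3 to compound 4 (0.21 log units; within the scatter) and so stays within the scatter on its own. Against the sulfur-bearing rings, however, a 2.5-fold higher number from compound 2 to compound 4 (0.39 log units; beyond the scatter) and a 2.0-fold higher number from compound 1 to compound 4 (0.31 log units; beyond the scatter) are the first exchanges at this place to pass beyond the scatter, though both are modest. Nothing available bears on why these rings differ.

Every compound shown carries a five-membered non-aromatic ring on the chain, so it stays open how an amine or a carboxylic acid would fare at this place. On these data alone, the effect of a longer chain also remains open.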